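The compounds below may be only part of what the source reports. "The series", "measured", "known", "first", "only" and "open" are said of these compounds alone.

Measured compounds:
- Compound 1 `C/C(=C\CC/C(C)=C/CC[C@@H]1[C@@]2(C)CCC(=O)C(C)(C)[C@H]2CC[C@@]1(C)O)CC/C=C(\C)C(=O)OCc1cn(-c2ccccc2Br)nn1`: in a functional assay on A549 cells (Homo sapiens) for antiproliferative activity, read by MTT assay, with a stated time of 48 h (on this read-out lower numbers stand for stronger inhibition and higher numbers for weaker inhibition), compound 1 gives only the assay limit > 150000 nM.
- Compound 2 `C/C(=C\CC/C(C)=C/CC[C@@H]1[C@@]2(C)CCC(=O)C(C)(C)[C@H]2CC[C@@]1(C)O)CC/C=C(\C)C(=O)OCc1cn(-c2cccc(Br)c2)nn1`: in this assay compound 2 gives only the assay limit > 150000 nM.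
- Compound 3 `C/C(=C\CC/C(C)=C/CC[C@@H]1[C@@]2(C)CCC(=O)C(C)(C)[C@H]2CC[C@@]1(C)O)CC/C=C(\C)C(=O)OCc1cn(-c2ccc(Br)cc2)nn1`: in this assay compound 3 gives only the assay limit > 150000 nM.

Compound 3 therefore stands at a limit, not at a number, and the two further values shown are limits as well (the limit of > 150000 nM in this assay, at which 3 of the 3 values shown sit). The steps among the measured compounds, a step that the two limits leave unreadable from compound 1 to compound 2, a step that the two limits leave unreadable from compound 1 to compound 3 and a step that the two limits leave unreadable from compound 2 to compound 3, are all unreadable in size, since both ends of each sit at the limit.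

Compound 4 `C/C(=C\CC/C(C)=C/CC[C@@H]1[C@@]2(C)CCC(=O)C(C)(C)[C@H]2CC[C@@]1(C)O)CC/C=C(\C)C(=O)OCc1cn(-c2cccc(C(F)(F)F)c2)nn1` is not yet measured. Its change from compound 3 is 3-(trifluoromethyl)phenyl in place of 4-bromophenyl on an aromatic nitrogen. All three measured steps change the substitution pattern of the bromophenyl on the aromatic nitrogen, and none of them is readable, so they give no usable size or direction for the present change; no step beyond the scatter can be derived from them.

For compound 4 the value in this assay is expected at about 150000 nM, with a range from 60000 nM to 400000 nM, most likely again reported only as a limit. The step this estimate implies is a number no higher from compound 3 to compound 4 (the limit leaves the size open), expected to be unreadable as well.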

Compound 4, half-maximal inhibitory concentration: > 150000 nM
Compound 4 gave a limit, no number; the forecaster's own chance of this, stated with the estimate: 80%; the middle value sits exactly at the limit.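

Among these compounds, compound 4 gives only a limit, so the steps to it from compound 1, compound 2 and compound 3 cannot be read and no new step follows: the limit of > 150000 nM in this assay, at which 4 of the 4 values shown sit. The compounds shown leave open at what concentration any of them inhibits, and whether the group on the aromatic nitrogen affects this.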